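The compounds below may be only part of what the source reports. "The series", "measured", "known", "first", "only" and "open" are said of these compounds alone.

Compound 1 `CCCCC(=O)OCc1ccc2oc(=O)c(C(=O)Oc3cccc(Br)c3)cc2c1` gives 63.3% in a functional assay on HT-1080 cells (Homo sapiens), read by transwell migration, with a stated time of 24 h, tested at 1 uM; a higher number here means a weaker effect of the compound at the concentration tested, a lower number a stronger effect. Compound 2 `CC(C)(C)C(=O)OCc1ccc2oc(=O)c(C(=O)Oc3cccc(Br)c3)cc2c1` gives 48.2%. Compound 3 `O=C(Oc1cccc(Cl)c1)c1cc2cc([N+](=O)[O-])ccc2oc1=O` gives 65.8%.

In this assay compound 3 stands highest of the three numbers, with compound 1 within the scatter of it and compound 2 the furthest, beyond the scatter. Among the compounds with values here, the one measured step, a number 15.1 percentage points lower from compound 1 to compound 2 (beyond the scatter), concerns an ester chain and not a halogen, so no measured step bears directly on the change to compound 4 `O=C(Oc1cccc(Br)c1)c1cc2cc([N+](=O)[O-])ccc2oc1=O`: bromo in place of chloro on an aromatic carbon. Compound 1, which carries the bromo group on a different core, sits within the scatter of compound 3. Compound 4 is therefore expected to move only within the scatter, a number 1.8 percentage points lower from compound 3 to compound 4 (within the scatter), and its estimated value is 64%, in a range from 50% to 78%.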

Compound 4, a percentage reported as activity, at one concentration (the size of the read-out at that concentration, not a potency): 35.2%
Beside the measured number, compound 4's estimate is 28.8 percentage points above it; the whole stated range lies above it.
By their numbers in this assay, from the lowest: compound 4; then compound 2; then compounds 1 and 3 (each within the scatter of the next).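

In this assay the change from 3-chlorophenyl to 3-bromophenyl gives a number 30.6 percentage points lower from compound 3 to compound 4 (beyond the scatter) and shows that this single halogen exchange can carry a large step on its own. With the 3-bromophenoxy group held constant, the group on the other side of the shared core also counts, with a number 13 percentage points lower from compound 2 to compound 4 (beyond the scatter) for one ester and a number 28.1 percentage points lower from compound 1 to compound 4 (beyond the scatter) for the other when nitro takes its place. The data shown offer no explanation for the size of the halogen step.

On these data alone, how fluoro, iodo or methyl would read at this place remains open. So does whether bromo in place of chloro gives a similar step with either ester on the core.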